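Dimethyl Sulfonamide on the Fluorinated Core: An Expected Dose

A few compounds are considered here, and "the series" means these few. Any claim that something is new, unique, unknown or untested is made for them only; others in the source may bear on it.

Measured so far:
compound 1, `CN(C)S(=O)(=O)Cc1noc2ccccc12` — 37 mg/kg
compound 2, `NS(=O)(=O)Cc1noc2ccc(F)cc12` — 15 mg/kg
compound 3, `CC(C)NS(=O)(=O)Cc1noc2ccc(F)cc12` — 38 mg/kg

In a functional assay on the whole organism (strain STD-dd) with Mus musculus as the target, in the maximal electroshock model, with a stated time of 2 h (on this read-out higher numbers stand for an effect only at larger amounts of compound and lower numbers for an effect already at smaller amounts), compound 3 stands at the top of the three numbers. Among the compounds with values here, compound 1 sits within the scatter of compound 3, while compound 2 lies further off, and the one step that connects these compounds, a 2.5-fold higher number from compound 2 to compound 3 (0.40 log units; beyond the scatter), shows a modest rise for isopropyl in place of hydrogen on a sulfonamide nitrogen.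

Compound 4, `CN(C)S(=O)(=O)Cc1noc2ccc(F)cc12`, differs from compound 3 by dimethylamino in place of isopropylamino on a sulfonyl sulfur. Within the data shown here, no measured step covers dimethylamino in place of isopropylamino. What the data do show is that compound 1, which carries dimethylamino on the core without fluorine, gives 37 mg/kg in this assay, and that figure sits within the scatter of compound 3 at 38 mg/kg. Since both substituted sulfonamides fall close together, the expected step of a 1.1-fold lower number from compound 3 to compound 4 (0.04 log units; within the scatter) is essentially none beyond the scatter. For compound 4 the estimated value in this assay is 35 mg/kg, with a range of 15 mg/kg to 80 mg/kg.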

Compound 4, dose for half-maximal effect: 32 mg/kg
For compound 4 the middle estimate is 1.1-fold (0.04 log units) above the measured one; the measured number falls inside the stated range.
By their numbers in this assay, from the lowest: compound 2; then compounds 4, 1 and 3 (each within the scatter of the next).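

In this assay, dimethylamino in place of isopropylamino on a sulfonyl sulfur gives a 1.2-fold lower number from compound 3 to compound 4 (0.07 log units; within the scatter), so the two substituted sulfonamides on the fluorinated core cannot be told apart, although only isopropylamino carries a hydrogen-bond donor. Dimethylamino in place of amino gives a 2.1-fold higher number from compound 2 to compound 4 (0.33 log units; beyond the scatter), a modest step in the same direction as the one seen for isopropylamino. Fluoro in place of hydrogen on an aromatic carbon, read here for the first time, gives a 1.2-fold lower number from compound 1 to compound 4 (0.06 log units; within the scatter), so with dimethylamino on the sulfur this change stays within the scatter.

Nothing available explains these numbers. Still open, on these data alone, is whether a longer chain such as n-butylamino, or a piperidine ring, on the sulfonyl sulfur would stay near these values, and whether chloro on the aromatic carbon would match fluoro.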